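Ester chain lengthening in a quinazoline-linked piperazine series

The source may hold more compounds than are shown below. What is called first, only, known or untested is meant among the compounds shown, and "the series" means these compounds.

Measured so far in a functional assay on A549 cells (Homo sapiens) for cytotoxicity, read by MTT assay, with a stated time of 24 h, tested at 20 uM; a lower number here means a stronger effect, a higher number a weaker effect of the compound at the concentration tested:
compound 1 `CCCCCCCCCOC(=O)CCC(=O)N1CCN(CCCOc2cc3c(Nc4ccc(F)c(Cl)c4)ncnc3cc2OC)CC1`: 79.7%
compound 2 `CCCCCCCCCCCCCOC(=O)CCC(=O)N1CCN(CCCOc2cc3c(Nc4ccc(F)c(Cl)c4)ncnc3cc2OC)CC1`: 93.8%
compound 3 `CCCCCCCCCCCCCCOC(=O)CCC(=O)N1CCN(CCCOc2cc3c(Nc4ccc(F)c(Cl)c4)ncnc3cc2OC)CC1`: 92.3%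

Compound 3 stands second highest of the three numbers; its nearest neighbour is compound 2, with a number 1.5 percentage points lower from compound 2 to compound 3 (within the scatter), and the furthest is compound 1, with a number 12.6 percentage points higher from compound 1 to compound 3 (beyond the scatter). Compound 4 `CCCCCCCCCCCCCCCCOC(=O)CCC(=O)N1CCN(CCCOc2cc3c(Nc4ccc(F)c(Cl)c4)ncnc3cc2OC)CC1` differs from compound 3 by ethyl in place of hydrogen on a saturated chain carbon, ten or more bonds along the chain from an oxygen next to a carbonyl group. The step that bears most directly on this is a number 1.5 percentage points lower from compound 2 to compound 3 (within the scatter), a change at the same place that stayed within the scatter. The larger steps of a number 14.1 percentage points higher from compound 1 to compound 2 (beyond the scatter) and a number 12.6 percentage points higher from compound 1 to compound 3 (beyond the scatter) start from the shorter chain of compound 1 and are only modest. For compound 4 no step beyond the scatter is expected, a number 0.3 percentage points lower from compound 3 to compound 4 (within the scatter). Compound 4 is estimated at 92%, with a range of 82% to 100%.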

Compound 4, a percentage reported as activity, at one concentration (the size of the read-out at that concentration, not a potency): 91.7%
Beside the measured number, compound 4's estimate is 0.3 percentage points above it; the range from low to high includes it.
By their numbers in this assay, from the lowest: compound 1; then compounds 4, 3 and 2 (each within the scatter of the next).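

In this assay, ethyl in place of hydrogen gives a number 0.6 percentage points lower from compound 3 to compound 4 (within the scatter) and propyl gives a number 2.1 percentage points lower from compound 2 to compound 4 (within the scatter), so the flat read-out seen between compound 2 and compound 3 extends to compound 4 at this place. Heptyl, nine bonds along the chain from an oxygen next to a carbonyl group, gives a number 12 percentage points higher from compound 1 to compound 4 (beyond the scatter), leaving compound 1 as the only one of the four set apart. No evidence bearing on the cause is available.

Open, from the compounds shown here alone, is where between the chains of compound 1 and compound 2 the read-out shifts. Also open, going by these compounds, is how a carboxylic acid in place of the ester would read.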